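Chloro for methoxy on the sulfonyl aryl ring

The source may report more compounds than this note shows. Statements on the series, on what has been measured and on what is new or still open speak of the compounds shown alone.

compound 1 `Cc1ccc(S(=O)(=O)c2cnc3ccc(F)cc3c2N2CCC(C)CC2)cc1F` — 86%
compound 2 `COc1cccc(S(=O)(=O)c2cnc3ccc(F)cc3c2N2CCC(C)CC2)c1` — 90%

Among these two numbers in an assay on isolated protein for displacement of a labelled ligand from metabotropic glutamate receptor 5 (Homo sapiens), with a stated time of 60 min, tested at 1 uM (a lower number here means less inhibition, a higher number more inhibition at the concentration tested (going by the name of the read-out)), compound 2 is separated from compound 1 only by a number 4 percentage points higher from compound 1 to compound 2 (within the scatter), so the two are indistinguishable. Compound 3 `CC1CCN(c2c(S(=O)(=O)c3cccc(Cl)c3)cnc3ccc(F)cc23)CC1` differs from compound 2 by chloro in place of methoxy on an aromatic carbon. For the measured compounds named here, the single measured step bearing on this ring, a number 4 percentage points higher from compound 1 to compound 2 (within the scatter), replaced one substituted phenyl with another and produced no real movement. On that basis the expected step to compound 3 is a number 3 percentage points lower from compound 2 to compound 3 (within the scatter), nothing beyond the scatter. Compound 3 is therefore estimated at 87%, within 72% to 96%.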

Compound 3, a percentage reported as inhibition, at one concentration (the size of the read-out at that concentration, not a potency): 92%
Estimate against measurement, compound 3: 5 percentage points below; measured number inside the range.
By their numbers in this assay, from the lowest: compounds 1, 2 and 3 (each within the scatter of the next).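

Replacing methoxy, with its hydrogen-bond acceptor, by chloro, which has none, gives a number 2 percentage points higher from compound 2 to compound 3 (within the scatter) in this assay, so the number stays level on losing that oxygen. The other comparison, a number 6 percentage points higher from compound 1 to compound 3 (within the scatter), adds 3-chlorophenyl to the aryl groups that cannot be told apart here. No measurement on these compounds offers an explanation for this.

Going by these compounds, whether a much larger group, such as an amine or a carboxylic acid, would also leave the inhibition unchanged at this place remains open.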